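Turning One Stereocentre: From Compound 2 to Compound 3

A few compounds are considered here, and "the series" means these few. Any claim that something is new, unique, unknown or untested is made for them only; others in the source may bear on it.

Compound 1 `COC(=O)[C@H]1CSCc2ccccc2C(=O)OC[C@@H](NC(=O)[C@@H]2CCCN2C(C)=O)CN1`: 2.9 10^-6 cm/s
Compound 2 `CO[C@@H]1CC[C@@H]2CCN(C)C(=O)[C@H](C)[C@H](OC)CN(C)C(=O)c3cccc(C#N)c3OC[C@@H]1O2`: 23.1 10^-6 cm/s

Of the compounds shown here, two have been measured in an ADME assay on Caco-2 cells (Homo sapiens) for permeability, read by LC-MS, in the apical to basolateral direction, with a stated time of 120 min, tested at 10 uM; a lower number here means that the compound crosses the layer more slowly, a higher number that the compound crosses the layer faster. Compound 2 gives 23.1 10^-6 cm/s, the higher of the two numbers. Compound 1 gives 2.9 10^-6 cm/s, a lower value, and the gap between compound 1 and compound 2 is beyond the usual scatter of such measurements. Among the measured compounds shown here, compound 1 and compound 2 have different cores, so their two values show only that compound 2 crosses the cell layer faster; they say nothing about which part of the structure is responsible.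

Compound 3 `CO[C@H]1CN(C)C(=O)c2cccc(C#N)c2OC[C@@H]2O[C@H](CC[C@H]2OC)CCN(C)C(=O)[C@@H]1C` has not yet been measured. It is built from the same atoms and bonds as compound 2: the two compounds have the same atoms and bonds and differ only in configuration as drawn: 1 of 5 stereo elements differ; a stereocentre at a saturated ring carbon is drawn S in compound 2 and R in compound 3. For the measured compounds named here, no pair of measured compounds differing only in configuration is available, so the effect of such a flip on permeability is unknown here. A change at a single stereocentre, with nothing entering or leaving the molecule, is expected to move the value little, and the step of a 1.2-fold lower number from compound 2 to compound 3 (0.06 log units; within the scatter) is expected to stay within the scatter. Compound 3 is therefore estimated at 20 10^-6 cm/s, in the range 10 10^-6 cm/s to 35 10^-6 cm/s.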

Compound 3, apparent permeability: 6.36 10^-6 cm/s
Compound 3: middle estimate off by 3.1-fold (0.50 log units), on the high side; the measured number lies below the stated range.
By their numbers in this assay, from the lowest: compound 1; then compound 3; then compound 2.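

Turning a single stereocentre at a saturated ring carbon from S to R gives, in this assay, a 3.6-fold lower number from compound 2 to compound 3 (0.56 log units; beyond the scatter). Among the compounds shown here, compound 1 and compound 2 have different cores, so the gap between them could not be tied to any one part of the structure, whereas this pair offers the first step that can be read at a single place. With nothing entering or leaving the molecule, the fall in the number can be assigned to this stereocentre alone, which shows that the spatial arrangement at this one position, and not only the set of atoms and bonds, matters for how fast these compounds cross the cell layer: the fact that compounds 2 and 3 differ only in the configuration as drawn

On these data alone, this single pair speaks for one stereocentre only, so it remains open whether turning any of the other stereo elements would move the number as far, or in the same direction. Also open, as far as these compounds go, is whether the gap between the S and R forms would survive if the nitrile gave way to another group, such as an amine or a carboxylic acid, and the data give no mechanism for the step.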